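The compounds below may be only part of what the source reports. "The series", "measured", "known", "first", "only" and "open" are said of these compounds alone.

Measured compounds, tolerance in an ADME assay on Li23 cells (Homo sapiens) for cytotoxicity, read by WST assay; a higher number here means that more compound is tolerated, a lower number that less compound is tolerated:
compound 1, `Cc1ccc(C(=O)N(C)c2ccc(C(O)(C(F)(F)F)C(F)(F)F)cc2)cc1`, gives 26000 nM
compound 2, `Cc1ccc(S(=O)(=O)N(C)c2ccc(C(O)(C(F)(F)F)C(F)(F)F)cc2)cc1`, gives 15000 nM

Compound 1 holds the highest of the two numbers in this assay; the nearest is compound 2, whose number lies within the scatter of that of compound 1, so the two are read as level rather than ordered. Compound 3, `CN(C(=O)Nc1ccccc1)c1ccc(C(O)(C(F)(F)F)C(F)(F)F)cc1`, differs from compound 1 in one place: anilino in place of 4-methylphenyl on a carbonyl carbon. For the measured compounds named here, no measured pair carries this change, so nothing of its size in this assay is known from the data. Both measured compounds sit at high tolerated concentrations with no separation beyond the scatter, and the change keeps the shared core and the carbonyl in place. The step from compound 1 to compound 3 is therefore expected to stay within the scatter, a 1.0-fold lower number from compound 1 to compound 3 (0.02 log units; within the scatter). Compound 3 is estimated at 25000 nM, with a range from 10000 nM to 60000 nM.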

Compound 3, half-maximal cytotoxic concentration: > 20000 nM
Compound 3: only a limit was reported (the forecaster's own chance of this, stated with the estimate: 20%); the middle value lies beyond the limit too.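

In this assay compound 3 gives > 20000 nM, a limit and not a number, so the step between compound 1 and compound 3 cannot be read. The compounds shown leave open whether anilino in place of 4-methylphenyl on a carbonyl carbon changes tolerance at all, and in which direction.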